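This account rests on a few compounds, and the source may have more. Where it says the series, first, only, none or still open, it means among the compounds named here.

Measured so far:
compound 1 `CO/N=c1\[nH]cnc2c1[n+](C/C=C(\C)CC/C=C(\C)CCC=C(C)C)cn2C`: 1160 nM
compound 2 `CC(C)=CCC/C(C)=C/CC/C(C)=C/CC/C(C)=C/C[n+]1cn(C)c2nc[nH]/c(=N\OC(C)(C)C)c21`: 3860 nM
compound 3 `CO/N=c1\[nH]cnc2c1[n+](C/C=C(\C)CC/C=C(\C)CC/C=C(\C)CCC=C(C)C)cn2C(C)C`: 2050 nM

In a functional assay on CEM/s cells (Homo sapiens) for cytotoxicity (a higher number here means a weaker inhibitor, a lower number a stronger inhibitor), compound 3 gives 2050 nM, the second highest of the three numbers. Its nearest neighbour is compound 1, which in this assay gives 1160 nM, a gap within the scatter. Compound 2 gives 3860 nM in this assay, also within the scatter of compound 3. Going by the values given here, no two measured compounds differ in one place, so no single-change step is known here.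

Compound 4 `CO/N=c1\[nH]cnc2c1[n+](C/C=C(\C)CC/C=C(\C)CC/C=C(\C)CCC=C(C)C)cn2CCC#N` is not yet measured. It differs from compound 3 by 2-cyanoethyl in place of isopropyl on an aromatic nitrogen. Nothing measured shows what such an exchange on that ring nitrogen does in this assay. Given the narrow band of the three numbers, the expected step is small, in no settled direction and likely within the scatter: a 1.2-fold higher number from compound 3 to compound 4 (0.07 log units; within the scatter). For compound 4 the estimate in this assay is 2400 nM, with a range from 900 nM to 6500 nM.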

Compound 4, half-maximal inhibitory concentration: 5360 nM
Estimate against measurement, compound 4: 2.2-fold (0.35 log units) below; low and high end bracket the measured number.
By their numbers in this assay, from the lowest: compounds 1, 3, 2 and 4 (each within the scatter of the next, the first and the last beyond it).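

In this assay, going by these compounds alone, 2-cyanoethyl in place of isopropyl on an aromatic nitrogen gives a 2.6-fold higher number from compound 3 to compound 4 (0.42 log units; beyond the scatter) and is the first single-change step. It shows that the group on this ring nitrogen can move the number beyond the scatter, here with the long chain of compound 3 held constant. The entering group brings a nitrile and one hydrogen-bond acceptor, but nothing available explains the step.

On these data alone, whether a plain propyl or a 2-hydroxyethyl group on this nitrogen would follow compound 4 or stay with compound 3 remains open. Also open, as far as these compounds go, is whether the same exchange gives a similar step with the shorter chain of compound 1.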